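Trifluoromethoxy terphenylpyridine diols: moving the hydroxyl

The source may hold more compounds than are shown below. What is called first, only, known or untested is meant among the compounds shown, and "the series" means these compounds.

Measured so far in a functional assay on HeLa cells (Homo sapiens) for inhibition; on this read-out higher numbers stand for weaker inhibition and lower numbers for stronger inhibition:
compound 1, `Oc1ccc(-c2cc(-c3cccc(F)c3)cc(-c3ccccc3O)n2)cc1`, > 50000 nM
compound 2, `Oc1ccc(-c2cc(-c3cccc(C(F)(F)F)c3)cc(-c3ccccc3O)n2)cc1`, > 50000 nM
compound 3, `Oc1cccc(-c2cc(-c3cccc(OC(F)(F)F)c3)cc(-c3ccccc3O)n2)c1`, 14900 nM

Compound 1 sits at the limit of this assay with > 50000 nM, which is not a number. Compound 2 likewise returns only a limit, > 50000 nM. Going by the values given here, the one step between measured compounds, a step that the two limits leave unreadable from compound 1 to compound 2, therefore cannot be sized. Among the compounds with values here, compound 3 is the only compound with a true number, 14900 nM, and so stands alone; the two others give (the limit of > 50000 nM in this assay, at which 2 of the 3 values shown sit).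

Compound 4, `Oc1ccc(-c2cc(-c3cccc(OC(F)(F)F)c3)cc(-c3ccccc3O)n2)cc1`, differs from compound 3 in one place: 4-hydroxyphenyl in place of 3-hydroxyphenyl on an aromatic carbon. No measured step bears directly on this change, since the one step that is shown concerns a different position and is unreadable from its two limits. Within the data shown here, what remains is that compound 3, the only compound with a number, is also the only one carrying 3-hydroxyphenyl, and that the two compounds at the limit do not. On that thin basis compound 4 is expected to move a 2.3-fold higher number from compound 3 to compound 4 (0.37 log units; beyond the scatter) in this assay, toward weaker inhibition, with a fair chance of reaching the limit. The estimate for compound 4 is 35000 nM, in the range 12000 nM to 100000 nM.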

Compound 4, half-maximal inhibitory concentration: > 50000 nM
Compound 4: no number, only a limit (the forecaster's own chance of this, stated with the estimate: 45%); at least 1.4-fold (0.15 log units) between middle value and limit.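

In this assay, going by these compounds alone, moving the hydroxyl gives the first readable step, an at least 3.3-fold higher number from compound 3 to compound 4 (0.52 log units; beyond the scatter), and that step lies beyond the scatter. The leaving 3-hydroxyphenyl and the entering 4-hydroxyphenyl have the same atoms and the same counts of hydrogen-bond donors and acceptors, so with trifluoromethoxy held fixed, the place of the hydroxyl alone separates a compound with a number from one without. Compound 4 gives > 50000 nM, which is a limit of the assay and not a number, so the full size of the step stays unknown, and the steps to compound 4 from compound 1 and from compound 2, with limits at both ends, cannot be read: the limit of > 50000 nM in this assay, at which 3 of the 4 values shown sit.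

Within the data shown here, it remains open whether 3-hydroxyphenyl would also bring a number with fluoro or trifluoromethyl on the other ring, as compound 3 is the only compound here that carries 3-hydroxyphenyl, and it does so with trifluoromethoxy. Also open, as far as these compounds go, is how a methoxy, an amine or a carboxylic acid in place of the hydroxyl on this ring would read in this assay.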